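The compounds below may be only part of what the source reports. "The series", "measured", "known", "first", "only" and "open" are said of these compounds alone.

Working notes on the series. Within the data shown here, in an assay on isolated protein for inhibition of Amine oxidase [flavin-containing] B (Homo sapiens) (a lower number here means a stronger inhibitor, a higher number a weaker inhibitor), compound 2 `CC(=O)N1N=C(c2ccc(O)cc2)CC1c1cccc(Cl)c1` gives 25000 nM, the lowest of the two numbers so far; the nearest neighbour, compound 1 `CC(=O)N1N=C(c2ccc(O)cc2)CC1c1ccccc1Cl`, gives 89000 nM. Among the measured compounds shown here, the only step measured, a 3.6-fold lower number from compound 1 to compound 2 (0.55 log units; beyond the scatter), is a shift of the chlorine within the chlorophenyl group and is the sole guide for the next change. Compound 3 `CC(=O)N1N=C(c2ccc(O)cc2)CC1c1ccc(Cl)cc1` differs from compound 2 by 4-chlorophenyl in place of 3-chlorophenyl on a saturated ring carbon. For the measured compounds named here, no second example of a change from 3-chlorophenyl to 4-chlorophenyl has been measured, so the direction is uncertain. Because a 3.6-fold lower number from compound 1 to compound 2 (0.55 log units; beyond the scatter) was a modest lowering, a further shift of the chlorine is expected to give in this assay at most a step of similar size, with no change beyond the scatter also plausible. Compound 3 is expected to give about 15000 nM in this assay, within 5000 nM to 50000 nM. The estimated step is a 1.7-fold lower number from compound 2 to compound 3 (0.22 log units; within the scatter).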

Compound 3, half-maximal inhibitory concentration: 40000 nM
Estimate against measurement, compound 3: 2.7-fold (0.43 log units) below; the range from low to high includes it.
By their numbers in this assay, from the lowest: compounds 2 and 3 (each within the scatter of the next); then compound 1.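

Moving the chlorine from 3-chlorophenyl to 4-chlorophenyl on the saturated ring carbon gives a 1.6-fold higher number from compound 2 to compound 3 (0.20 log units; within the scatter) in this assay, so these two placements cannot be told apart in this assay. The 2-chlorophenyl group now stands apart from both others, as the second comparison shows a 2.2-fold lower number from compound 1 to compound 3 (0.35 log units; beyond the scatter), so the earlier difference was not specific to 3-chlorophenyl; among these three compounds, only compound 1 separates from the rest. No supporting evidence bears on why the chlorine placement gives this result.

Open, on these data alone, is whether replacing the chlorine with a methoxy group or an amine would move the number beyond the scatter of compound 2 and compound 3. Also open, as far as these compounds go, is how a longer acyl chain in place of the acetyl group would bear on the number.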